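A few compounds are considered here, and "the series" means these few. Any claim that something is new, unique, unknown or untested is made for them only; others in the source may bear on it.

Measured in an ADME assay on microsomes from liver (Rattus norvegicus) for metabolic stability, read by LC-MS, with a stated time of 1 h, at 37 degrees C, tested at 4 uM; on this read-out lower numbers stand for a less stable compound and higher numbers for a more stable compound:
- Compound 1 `Cn1sc2cc(OCc3cccc(-c4ccc(Cl)c(C(=O)O)c4)c3)ccc2c1=O`: 84%
- Compound 2 `O=C1c2ccc(OCc3cccc(-c4ccccc4)c3)cc2CN1C1CCCC1`: 38%

Compound 2 has the lower of these two numbers, and its gap to compound 1 lies beyond the usual scatter. Compound 3 `O=C(O)c1cc(-c2cccc(COc3ccc4c(c3)CN(C3CCCC3)C4=O)c2)ccc1O` differs from compound 2 in one place: 3-carboxy-4-hydroxyphenyl in place of phenyl on an aromatic carbon. In words, 3-carboxy-4-hydroxyphenyl stands in place of phenyl on an aromatic carbon. For the measured compounds named here, no measured pair shows this change directly. Compound 1 also bears a carboxy group and gives 84%, so an upward step of uncertain size is expected in this assay. The expected change is a number 30 percentage points higher from compound 2 to compound 3 (beyond the scatter). For compound 3 the estimated value is 68%, with an expected range from 42% to 90%.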

Compound 3, percent of the compound remaining: 9%
Estimate against measurement, compound 3: 59 percentage points above, outside the stated range (below it).
By their numbers in this assay, from the lowest: compound 3; then compound 2; then compound 1.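

In this assay, 3-carboxy-4-hydroxyphenyl in place of phenyl on an aromatic carbon gives a number a number 29 percentage points lower from compound 2 to compound 3 (beyond the scatter) and so makes a clear difference to how much compound remains. For the compounds shown here, this is the first measured step, and it shows that what is attached at this position can matter to the read-out, with the change here going towards a less stable compound. The compounds shown leave open how a simple amine or a methoxy group at this position would read, and whether the carboxy or the hydroxy part accounts for the drop. Nothing measured here explains the drop.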